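The source may hold more compounds than are shown below. What is called first, only, known or untested is meant among the compounds shown, and "the series" means these compounds.

Measured so far in a physicochemical assay for lipophilicity (a lower number here means a more polar compound, a higher number a more lipophilic compound), for compounds that share one core:

Compound 1 `C[C@H]1CC[C@@H]2[C@@H](OC(=O)[C@]23CC(c2ccc(F)cc2)N(c2ccccc2)O3)[C@]2(C)C(=O)C=C[C@@]12O` gives 3.35
Compound 2 `C[C@H]1CC[C@@H]2[C@@H](OC(=O)[C@]23CC(c2ccc(C#N)cc2)N(c2ccccc2)O3)[C@]2(C)C(=O)C=C[C@@]12O` gives 2.94
Compound 3 `C[C@H]1CC[C@@H]2[C@@H](OC(=O)[C@]23CC(c2c(Cl)cccc2Cl)N(c2ccccc2)O3)[C@]2(C)C(=O)C=C[C@@]12O` gives 4.45

Compound 3 stands highest of the three, clearly above both of the others. Compound 4 `C[C@H]1CC[C@@H]2[C@@H](OC(=O)[C@]23CC(c2c(F)c(F)c(F)c(F)c2F)N(c2ccccc2)O3)[C@]2(C)C(=O)C=C[C@@]12O` has not been measured yet. It differs from compound 3 in one place, a saturated ring carbon, where 2,3,4,5,6-pentafluorophenyl stands in place of 2,6-dichlorophenyl (2,3,4,5,6-pentafluorophenyl in place of 2,6-dichlorophenyl on a saturated ring carbon).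

Two measured steps changed the group at this same carbon, and both are large. Putting 2,6-dichlorophenyl in place of 4-fluorophenyl gave a number 1.10 log units higher from compound 1 to compound 3 (beyond the scatter) and putting it in place of 4-cyanophenyl gave a number 1.51 log units higher from compound 2 to compound 3 (beyond the scatter) in this assay as well. A smaller change, cyano in place of fluoro on an aromatic carbon, gave a number 0.41 log units lower from compound 1 to compound 2 (beyond the scatter) and counts as modest.

Going by the values given here, no measured compound carries pentafluorophenyl, so this forecast is rough. Among the compounds with values here, the only fluorine-bearing group measured at this carbon, in compound 1 (3.35), sits well under the dichlorinated case, which points downward from compound 3. The expected result is a number 0.50 log units lower from compound 3 to compound 4 (beyond the scatter) and that would be a modest step. For compound 4 the estimate is 3.95 with 3.5 to 4.4 as the expected range.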

Compound 4, partition coefficient: 3.72
Estimate against measurement, compound 4: 0.23 log units above, and the stated range covers the measured number.
By their numbers in this assay, from the lowest: compound 2; then compound 1; then compound 4; then compound 3.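

In this assay, going by these compounds alone, the change at this saturated ring carbon gives a number 0.73 log units lower from compound 3 to compound 4 (beyond the scatter) and also a number 0.37 log units higher from compound 1 to compound 4 (beyond the scatter) and so fills the wide gap that the earlier compounds left between the 4-fluorophenyl and 2,6-dichlorophenyl groups. Measured against the 4-cyanophenyl group, the same carbon gives a number 0.78 log units higher from compound 2 to compound 4 (beyond the scatter) and this shows that the ring at this carbon can set an intermediate reading, not only the extremes seen before. Adding fluorine around the ring therefore does not match the 2,6-dichlorophenyl group here, even though 2,3,4,5,6-pentafluorophenyl has more heavy atoms, and no measurement shown explains this order.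

Compound 3 and compound 4 differ in both the kind of halogen and how many halogens the ring carries, so this step cannot separate those two changes, and a 2,6-difluorophenyl group would help to pull them apart. On these data alone, it also remains open where a phenyl ring bearing an amine or a carboxylic acid would fall at this carbon, or how a longer alkyl chain in place of the ring would read.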